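This account rests on a few compounds, and the source may have more. Where it says the series, first, only, none or still open, it means among the compounds named here.

Measured compounds:
- compound 1, `O=C(/C=C/c1cccc(NC(=O)Nc2ccccc2)c1)C[C@@H]1O[C@H](CO)[C@@H](O)[C@H](O)[C@@H]1O`: "not determined" (no result reported)
- compound 2, `CC(=O)OC[C@H]1O[C@@H](CC(=O)/C=C/c2ccc(NC(=O)Nc3ccccc3)cc2)[C@H](OC(C)=O)[C@@H](OC(C)=O)[C@@H]1OC(C)=O`: 820000 nM

In an ADME assay on Vero cells (Chlorocebus sabaeus) for cytotoxicity, read by resazurin assay, with a stated time of 2 days (a higher number here means that more compound is tolerated, a lower number that less compound is tolerated), compound 2 gives 820000 nM, a concentration far up the range, so the tetraacetylated member of the series is well tolerated by these cells. Compound 1 stands without a number in this assay; nothing can be said of its own tolerance, and compound 2 is the only reference point. Compound 3, `Cc1ccc(S(=O)(=O)Nc2cccc(/C=C/C(=O)C[C@@H]3O[C@H](CO)[C@@H](O)[C@H](O)[C@@H]3O)c2)cc1`, differs from compound 1 by (4-methylphenyl)sulfonyl in place of phenylcarbamoyl on a nitrogen on an aromatic ring. With no step between measured compounds shown, no size or direction of change can be read from the series; the one value available suggests compounds of this core are tolerated at high concentration, and no change beyond the scatter is expected from the swap. Compound 3 is therefore expected to give about 500000 nM in this assay, with a plausible range from 150000 nM to 1500000 nM, and a real chance that only a limit is reported.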

Compound 3, half-maximal cytotoxic concentration: 417000 nM
The estimate for compound 3 lay 1.2-fold (0.08 log units) above the measured number; the measured number falls inside the stated range.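

For the compounds shown here, no step from compound 1 to compound 3 can be read in this assay, and compound 3 stands at 417000 nM without a comparison partner. On these data alone, the effect on tolerance of (4-methylphenyl)sulfonyl in place of phenylcarbamoyl stays open. No supporting evidence bears on this result.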